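The source may hold more compounds than are shown below. What is called first, only, known or untested is meant among the compounds shown, and "the series" means these compounds.

Measured compounds in a functional assay on HeLa cells (Homo sapiens) for inhibition, read by cell counting, with a stated time of 4 days; a higher number here means a weaker inhibitor, a lower number a stronger inhibitor:
compound 1 `Nc1cccc(-c2cn3nc(-c4cccs4)sc3n2)c1` — > 250000 nM (a limit of this assay)
compound 2 `Nc1cccc(-c2cn3nc(CCc4ccccc4)sc3n2)c1` — 242000 nM
compound 3 `Nc1cccc(-c2cn3nc(Cc4ccccc4)sc3n2)c1` — 24000 nM

Compound 1 reports only a limit in this assay, > 250000 nM; that is all its value shows (the limit of > 250000 nM in this assay, at which 1 of the 3 values shown sits). Compound 3 holds the lowest of the two numbers in this assay, with compound 2 the nearest at a higher number.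

The two steps into compound 3 both end in a lower number: an at least 10-fold lower number from compound 1 to compound 3 (1.01 log units; beyond the scatter), and a 10-fold lower number from compound 2 to compound 3 (1.00 log units; beyond the scatter). Both steps lead from a directly attached aromatic ring, or from a longer chain, to the benzyl group.

Compound 4 `Nc1cccc(-c2cn3nc(-c4ccc(F)cc4)sc3n2)c1` differs from compound 3 by 4-fluorophenyl in place of benzyl on an aromatic carbon. This reverses the sense of the step from compound 1 to compound 3: an aromatic ring again sits directly on the core carbon, as in compound 1, which gives only a limit in this assay. The step from compound 1 to compound 3 was large, so a higher number is expected for compound 4 in this assay, of roughly comparable size, with a real chance that only a limit is reported.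

Compound 4 is therefore estimated at 150000 nM in this assay, within 40000 nM to 260000 nM, an expected step of a 6.3-fold higher number from compound 3 to compound 4 (0.80 log units; beyond the scatter).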

Compound 4, half-maximal inhibitory concentration: >= 250000 nM
Compound 4 ended at the assay's limit; the forecaster's own chance of this, stated with the estimate: 35%; at least 1.6-fold (0.22 log units) between middle value and limit.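

In this assay, replacing benzyl with 4-fluorophenyl on this aromatic carbon gives an at least 10-fold higher number from compound 3 to compound 4 (1.01 log units; beyond the scatter), although both groups have the same heavy-atom count, one six-membered aromatic ring of carbon only, no hydrogen-bond donors or acceptors and no net charge. Compound 4 gives only a limit: the limit of >= 250000 nM in this assay, at which 1 of the 4 values shown sits.
With compound 1 also at a limit, the poor result for a ring set directly on the core carbon is no longer confined to thiophen-2-yl, now extending to a six-membered aromatic ring, but the two limits leave the step between compound 1 and compound 4 unreadable.

The change from compound 3 to compound 4 removes the methylene link and adds fluorine at once, so a plain phenyl or a 4-fluorobenzyl group on the same carbon would be needed to separate the two. Also open, on these data alone, is whether an ether oxygen or an amine nitrogen in place of the benzyl carbon link would retain the value of compound 3, 24000 nM in this assay.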